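The source may report more compounds than this note shows. Statements on the series, on what has been measured and on what is new or still open speak of the compounds shown alone.

In a functional assay on RS4-11 cells (Homo sapiens) for inhibition, read by CCK-8 assay, with a stated time of 48 h (on this read-out higher numbers stand for weaker inhibition and lower numbers for stronger inhibition), compound 1 `O=S(=O)(NCCNC(=S)Nc1cccc(Cl)c1)c1ccc(-c2ccccc2OCc2cccc(O)c2)s1` gives 5800 nM. Among the compounds with values here, compound 3 `COc1ccc(Oc2ccc(C(C)C)cc2-c2ccsc2S(=O)(=O)NCCNC(=O)Nc2cc(Cl)cc(Cl)c2)cc1OC` gives 9000 nM, which lies within the usual scatter of the number for compound 1, and these two are the only true numbers so far. In this assay compound 2 `COc1ccc(Oc2ccc([N+](=O)[O-])cc2-c2ccsc2S(=O)(=O)N2CCN(C(=S)Nc3ccc(Cl)cc3)CC2)cc1OC` is reported only as a limit, > 50000 nM. Compound 4 `O=C(NCCNS(=O)(=O)c1ccc(-c2ccccc2OCc2cccc(O)c2)s1)Nc1cc(Cl)cc(Cl)c1` remains unmeasured, and its difference from compound 1 is this: a group of 11 heavy atoms (7 carbon, 1 nitrogen, 1 oxygen, 2 chlorine; one six-membered aromatic ring of carbon only) in place of a group of 10 heavy atoms (7 carbon, 1 nitrogen, 1 sulfur, 1 chlorine; one six-membered aromatic ring of carbon only), on an amine nitrogen. Compound 3 also carries (3,5-dichlorophenyl)carbamoyl and gives 9000 nM, so no change beyond the scatter is expected in this assay. The expected step is a 1.1-fold higher number from compound 1 to compound 4 (0.05 log units; within the scatter). For compound 4 the estimated value is 6500 nM, with an expected range from 2500 nM to 17000 nM.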

Compound 4, half-maximal inhibitory concentration: > 50000 nM
Compound 4 ended at the assay's limit; the forecaster's own chance of this, stated with the estimate: 5%; middle value at least 7.6-fold (0.88 log units) from the limit.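

In this assay, placing (3,5-dichlorophenyl)carbamoyl on this amine nitrogen, in place of the group with one chlorine and one sulfur, gives an at least 8.6-fold higher number from compound 1 to compound 4 (0.93 log units; beyond the scatter). Within the data shown here, the earlier compounds offered no step at this position, so this is the first change here that can be read, and it lies beyond the scatter. The reading for compound 4 is a limit, so the full size of the step stays unknown, and this limit is shared: the limit of > 50000 nM in this assay, at which 2 of the 4 values shown sit.

From the compounds shown here alone, whether the second chlorine or the exchange of sulfur for oxygen matters stays open, since both change together. Also open, going by these compounds, is what an acetyl group or a pyridine ring would do on this nitrogen.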